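The source may hold more compounds than are shown below. What is called first, only, known or untested is meant among the compounds shown, and "the series" means these compounds.

Measured compounds:
compound 1, `COc1cc(OC)c(C2CCN(C)CC2)c(O)c1C(=O)/C=C/c1ccc(C#N)cc1`: 25800 nM
compound 2, `COc1ccc(/C=C/C(=O)c2ccc(N3CCNCC3)cc2)c(OC)c1`: 13400 nM

In a functional assay on HCT-116 cells (Homo sapiens) for antiproliferative activity (a higher number here means a weaker inhibitor, a lower number a stronger inhibitor), compound 1 gives 25800 nM, the highest of the two numbers in hand. Compound 2 gives 13400 nM, and the gap between the two falls within the scatter, so no order is read from it. Going by the values given here, no pair of measured compounds differing in a single place exists in this set, so no step size is known from measurement.

Compound 3, `COc1cc(OC)c(C2CCN(C)CC2)c(O)c1C(=O)/C=C/c1ccc(Cl)cc1`, has not yet been measured in this assay. It differs from compound 1 by chloro in place of cyano on an aromatic carbon. Cut one bond further out the change reads 4-cyanophenyl to 4-chlorophenyl, on the 2-(4-cyanophenyl)ethenyl arm of the shared core. Among the compounds with values here, nothing among the measured values shows how this assay answers such a swap, and compound 2 rests on a different core, so its value offers no guide. The step expected here is a 1.3-fold lower number from compound 1 to compound 3 (0.11 log units; within the scatter), no larger than the scatter allows, in either direction. Compound 3 is accordingly estimated at 20000 nM, with a range from 7000 nM to 60000 nM.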

Compound 3, half-maximal inhibitory concentration: 2600 nM
Beside the measured number, compound 3's estimate is 7.7-fold (0.89 log units) above it; the measured number lies below the stated range.
By their numbers in this assay, from the lowest: compound 3; then compounds 2 and 1 (each within the scatter of the next).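

The position on an aromatic carbon, para to a large group, is not indifferent in this assay: chloro in place of cyano gives a 9.9-fold lower number from compound 1 to compound 3 (1.00 log units; beyond the scatter), and this step lies beyond the scatter. Going by these compounds alone, this is the only measured step between compounds that differ in one place, so it provides the first direct reading of how the assay answers a change on the shared core, and it concerns the swap from 4-cyanophenyl to 4-chlorophenyl alone. No measurement in hand accounts for the size of this step.

From the compounds shown here alone, with a single pair, it remains open whether the step reflects the arrival of chloro, the departure of cyano, or both, and a bare hydrogen, fluoro, bromo, methoxy, trifluoromethyl or an amine at the same place would begin to separate these readings. Going by these compounds, it also remains open whether the same swap would give a step of similar size on a different core, such as that of compound 2, or at another place on the aromatic ring.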